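Hydrogen in place of methoxy on compound 2

A few compounds are considered here, and "the series" means these few. Any claim that something is new, unique, unknown or untested is made for them only; others in the source may bear on it.

In an ADME assay on microsomes from liver (Homo sapiens) for metabolic stability, read by LC-MS, using NADPH, with a stated time of 60 min, tested at 1 uM (on this read-out higher numbers stand for fast clearance and lower numbers for slow clearance), compound 1 `COc1ccc(S(=O)(=O)N2CCC[C@H]2C(=O)O[C@@H](Cc2c(Cl)c[n+]([O-])cc2Cl)c2ccc(OC(F)F)c(OCC3CC3)c2)cc1C(=O)N(C)C` gives 365 mL.min-1.g-1 and compound 2 `COc1ccc(S(=O)(=O)N2CCCC[C@H]2C(=O)O[C@@H](Cc2c(Cl)c[n+]([O-])cc2Cl)c2ccc(OC(F)F)c(OCC3CC3)c2)cc1C(=O)N(C)C` gives 244 mL.min-1.g-1. These two values lie within the scatter of each other, so both compounds stand at the same level on the two numbers available.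

Compound 3 `CN(C)C(=O)c1cccc(S(=O)(=O)N2CCCC[C@H]2C(=O)O[C@@H](Cc2c(Cl)c[n+]([O-])cc2Cl)c2ccc(OC(F)F)c(OCC3CC3)c2)c1` derives from compound 2 through one change, (hydrogen in place of methoxy on an aromatic carbon). In words, this is hydrogen in place of methoxy on an aromatic carbon, ortho to a dimethylcarbamoyl group.

Among the measured compounds shown here, no measured pair carries this change, so the data offer no direct guide to its size or direction. The closest anchor is compound 2 at 244 mL.min-1.g-1. No shift beyond the scatter is expected, and the estimated step is a 1.1-fold lower number from compound 2 to compound 3 (0.03 log units; within the scatter). Compound 3 is estimated at 230 mL.min-1.g-1, with an expected range of 110 mL.min-1.g-1 to 460 mL.min-1.g-1.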

Compound 3, intrinsic clearance in microsomes: 363 mL.min-1.g-1
The estimate for compound 3 lay 1.6-fold (0.20 log units) below the measured number; the measured number falls inside the stated range.
By their numbers in this assay, from the lowest: compounds 2, 3 and 1 (each within the scatter of the next).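

Hydrogen in place of methoxy gives a 1.5-fold higher number from compound 2 to compound 3 (0.17 log units; within the scatter) in this assay, the first measured step at this position, ortho to a dimethylcarbamoyl group. On the background of compound 2, the methoxy group can therefore be lost with no shift that stands clear of the usual scatter, although this rests on a single pair. Nothing measured here bears on the mechanism of clearance in this series or on the role of this position in it.

On these data alone, whether an amine, a carboxylic acid or a longer alkoxy chain at this position would move the clearance beyond the scatter remains open. As far as these compounds go, it is also open whether the same exchange on compound 1 would give a step of similar size and direction.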